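Replacing the carboxylated side chain on the amine nitrogen

The compounds below may be only part of what the source reports. "The series", "measured", "known", "first", "only" and "open" are said of these compounds alone.

In a functional assay on HeLa cells (Homo sapiens) for antiproliferative activity, read by CCK-8 assay, with a stated time of 48 h (on this read-out higher numbers stand for weaker inhibition and lower numbers for stronger inhibition), compound 1 `COc1ccc(/C=C\c2cc(OC)c(OC)c(OC)c2)cc1OCc1ccc(CN2CCCC[C@H]2C(=O)O)cc1` gives > 10000 nM as a limit of the assay and not a number. Compound 2 `COc1ccc(/C=C\c2cc(OC)c(OC)c(OC)c2)cc1OCc1ccc(CN[C@H](C(=O)O)[C@H](C)O)cc1` gives > 10000 nM which is likewise a limit, so compound 2 has no number of its own. Compound 3 `COc1ccc(/C=C\c2cc(OC)c(OC)c(OC)c2)cc1OCc1ccc(CNCCO)cc1` differs from compound 2 by 2-hydroxyethyl in place of 1-carboxy-2-hydroxypropyl on an amine nitrogen with 2-hydroxyethyl in place of 1-carboxy-2-hydroxypropyl on an amine nitrogen. Within the data shown here, the one measured step is a step that the two limits leave unreadable from compound 1 to compound 2 and gives no size to carry over. The only level seen so far is the limit of > 10000 nM in this assay, at which 2 of the 2 values shown sit, and compound 1 and compound 2 both carry a carboxy group, which compound 3 lacks. A move toward stronger inhibition is therefore expected, though its size is poorly fixed, and the estimated move is an at least 6.6-fold lower number from compound 2 to compound 3 (0.82 log units; beyond the scatter) with another limit still possible. In this assay compound 3 is expected at 1500 nM with an estimated range from 100 nM to 10000 nM as a working figure.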

Compound 3, half-maximal inhibitory concentration: 4400 nM
Beside the measured number, compound 3's estimate is 2.9-fold (0.47 log units) below it; the range from low to high includes it.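

In this assay, this position on the amine nitrogen now shows a readable change: 2-hydroxyethyl in place of 1-carboxy-2-hydroxypropyl gives an at least 2.2-fold lower number from compound 2 to compound 3 (0.35 log units; beyond the scatter), and (2-hydroxyethyl)amino in place of 2-carboxypiperidin-1-yl gives an at least 2.2-fold lower number from compound 1 to compound 3 (0.35 log units; beyond the scatter). Among these compounds, the step between compound 1 and compound 2 cannot be read, so compound 3 is the first compound here to give a number rather than a limit. Among these three compounds, only compound 1 and compound 2 carry a carboxy group, and both sit at the same limit: the limit of > 10000 nM in this assay, at which 2 of the 3 values shown sit.

The change to compound 3 removes the carboxy group and also shortens the side chain, so the compounds shown do not separate these two changes. Still open, as far as these compounds go, is how carboxymethyl, 3-hydroxypropyl or plain ethyl would read on the same nitrogen.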